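Tert-butyl in place of dimethylamino: an open step

The source may hold more compounds than are shown below. What is called first, only, known or untested is meant among the compounds shown, and "the series" means these compounds.

In a functional assay on HepG2 cells (Homo sapiens) for antiproliferative activity, read by MTT assay, with a stated time of 48 h (on this read-out lower numbers stand for stronger inhibition and higher numbers for weaker inhibition), compound 1 `COc1ccc(NC(=O)Nc2cccc(CNc3nccnc3Cl)c2)cc1` gives 12000 nM. Compound 2 `CN(C)c1ccc(NC(=O)Nc2cccc(CNc3nccnc3Cl)c2)cc1` reaches only a limit of the assay, > 40000 nM, so it has no exact number. Compound 3 `CC(C)(C)c1ccc(NC(=O)Nc2cccc(CNc3nccnc3Cl)c2)cc1` carries tert-butyl in place of dimethylamino on an aromatic carbon, para to a large group: tert-butyl in place of dimethylamino on an aromatic carbon. Within the data shown here, one measured step bears on this change at the same place: an at least 3.3-fold higher number from compound 1 to compound 2 (0.52 log units; beyond the scatter), beyond the scatter, with dimethylamino entering in place of methoxy. Removing dimethylamino might therefore reverse that loss, at least in part, although methoxy and tert-butyl are different groups and the limit leaves the true size of the measured step open. The expected change is an at least 2.6-fold lower number from compound 2 to compound 3 (0.42 log units; beyond the scatter), towards stronger inhibition in this assay. Compound 3 is estimated at 15000 nM, with an expected range of 5000 nM to 40000 nM.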

Compound 3, half-maximal inhibitory concentration: 7550 nM
Estimate against measurement, compound 3: 2.0-fold (0.30 log units) above; the range from low to high includes it.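

At this place, para to a large group, tert-butyl in place of dimethylamino gives an at least 5.2-fold lower number from compound 2 to compound 3 (0.72 log units; beyond the scatter) in this assay, so the loss seen with dimethylamino does not extend to every group here. Against methoxy, tert-butyl gives a 1.6-fold lower number from compound 1 to compound 3 (0.20 log units; within the scatter), which leaves these two groups level on this read-out, while dimethylamino alone of the three falls away. The true size of the step from dimethylamino stays unknown, since compound 2 has only a limit of the assay: the limit of > 40000 nM in this assay, at which 1 of the 3 values shown sits.

The compounds shown leave open how a carboxylic acid, a primary amine or a longer alkyl chain would read at this place. From the compounds shown here alone, all three also share one core, so what a change elsewhere in it would do remains unknown.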